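Swapping a Cyclopentyloxy Group for Nitro

The source may report more compounds than this note shows. Statements on the series, on what has been measured and on what is new or still open speak of the compounds shown alone.

Compound 1, `Cc1cccc(N2CCN(c3cc(C(F)(F)F)ccc3CNC(=O)C(C)c3ccc(NS(C)(=O)=O)c(F)c3)CC2)c1`: 1.8 nM
Compound 2, `CC(C(=O)NCc1ccc(C(F)(F)F)cc1OC1CCCC1)c1ccc(NS(C)(=O)=O)c(F)c1`: 0.6 nM

Of the compounds shown here, two have been measured in an assay on CHO cells for antagonist activity at transient receptor potential cation channel subfamily V member 1 (Homo sapiens), read by FLIPR; a lower number here means a stronger inhibitor, a higher number a weaker inhibitor. Compound 1 gives 1.8 nM. Compound 2 gives 0.6 nM, the lower of the two numbers, and its gap to compound 1 lies beyond the usual scatter. The next compound, compound 3 `CC(C(=O)NCc1ccc(C(F)(F)F)cc1[N+](=O)[O-])c1ccc(NS(C)(=O)=O)c(F)c1`, is not yet measured. It keeps the whole of compound 2 except for one change: nitro in place of cyclopentyloxy on an aromatic carbon. Within the data shown here, the cyclopentyloxy group is much larger than the nitro that replaces it, and the series offers no measured step of this kind, so the direction must be guessed. A moderate loss of inhibition is expected, a step of an 8.3-fold higher number from compound 2 to compound 3 (0.92 log units; beyond the scatter). Compound 3 is therefore estimated at 5 nM, with a range from 1.5 nM to 20 nM.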

Compound 3, inhibition constant: "not active" (no number reported)
Compound 3: no number reported; no gap can be computed for the estimate.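

In this assay, among these compounds, compound 3 is reported as "not active" without a number, so no step from compound 2 to compound 3 can be read. How much inhibition changes with nitro in place of cyclopentyloxy stays open, and no data shown explain the result.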